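The source may report more compounds than this note shows. Statements on the series, on what has been measured and on what is new or still open speak of the compounds shown alone.

Series notes. Compound 2 `COc1ccc2oc(N3CCN(C)CC3)nc2c1` carries a methoxy on the six-membered aromatic ring of carbon only of the shared core; in an assay on ileum (strain Hartley) with 5-hydroxytryptamine receptor 3A (Cavia porcellus) as the target (on this read-out higher numbers stand for larger maximal responses and lower numbers for smaller maximal responses), compound 2 gives 0.78, the highest of the three numbers measured. Compound 1 `CN1CCN(c2nc3cccc(Cl)c3o2)CC1` gives 0.24 and compound 3 `CCc1cccc2nc(N3CCN(C)CC3)oc12` gives 0.15, each beyond the scatter below compound 2. For the measured compounds named here, the single one-place step among the measured compounds, a number 0.090 lower from compound 1 to compound 3 (within the scatter), exchanges ethyl for chloro and stays within the scatter.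

Compound 4 `CN1CCN(c2nc3cc([N+](=O)[O-])ccc3o2)CC1` is the next case and differs from compound 2 in one place: nitro in place of methoxy on an aromatic carbon. Going by the values given here, no measured step concerns nitro or methoxy, and none concerns this place on the ring, so the measured steps bear on it only indirectly. The step from compound 1 to compound 3 shows that swapping one small group for another on an aromatic carbon can leave the maximal response essentially unchanged, while the gaps from compound 2 to compound 1 and to compound 3 show that the substitution pattern does move this read-out. With nitro counted differently from methoxy, a fall beyond the scatter is the more likely outcome, though with wide uncertainty. The step from compound 2 to compound 4 is estimated at a number 0.28 lower from compound 2 to compound 4 (beyond the scatter). Compound 4 is accordingly expected at 0.5, with a range from 0.2 to 0.8.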

Compound 4, intrinsic activity: the largest response reached, as a fraction of the reference agonist's: 0.52
Beside the measured number, compound 4's estimate is 0.020 below it; low and high end bracket the measured number.
By their numbers in this assay, from the lowest: compounds 3 and 1 (each within the scatter of the next); then compound 4; then compound 2.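

In this assay, for the compounds shown here, the place on the six-membered aromatic ring of carbon only that holds methoxy in compound 2 proves sensitive to the group it carries: nitro in place of methoxy gives a number 0.26 lower from compound 2 to compound 4 (beyond the scatter). Going by these compounds alone, this is the first one-place change to move the maximal response beyond the scatter, whereas the only earlier step, ethyl in place of chloro on an aromatic carbon, gave a number 0.090 lower from compound 1 to compound 3 (within the scatter) and stayed within it. The change lowers the response without removing it, as compound 4 still gives 0.52, so a substantial maximal response is kept with either of the two groups at this place.

No measured property of methoxy or nitro is available to explain the size of this step. Within the data shown here, with only two groups compared at this place, it remains open whether the maximal response follows a trend across groups or simply differs between these two, and an amine, a carboxylic acid or a longer chain such as propoxy at the same ring carbon would test how far the response can move.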